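The compounds below may be only part of what the source reports. "The series", "measured", "known", "first", "only" and "open" are said of these compounds alone.

Four compounds share one core and differ at only two points: the ring attached to the amide nitrogen, and the group on the six-membered aromatic ring of carbon only. Compound 1 `COc1ccc(-c2cn(CC(=O)Nc3cc(C)on3)nn2)cc1` carries a methoxy group on that ring and a 5-methyl-1,2-oxazol-3-yl on the amide nitrogen. In a functional assay on BMDM cells (Mus musculus, strain C57BL/6) for inhibition, with a stated time of 2 days (a lower number here means a stronger inhibitor, a higher number a weaker inhibitor), compound 1 gives > 30000 nM, which is a limit of the assay rather than a number. Compound 2 `COc1ccc(-c2cn(CC(=O)Nc3nc(C)cs3)nn2)cc1` differs from compound 1 by 4-methyl-1,3-thiazol-2-yl in place of 5-methyl-1,2-oxazol-3-yl on an amide-type nitrogen. In this assay compound 2 gives 3890 nM. That change brought an at least 7.7-fold lower number from compound 1 to compound 2 (0.88 log units; beyond the scatter); its true size is hidden because of the limit of > 30000 nM in this assay, at which 2 of the 3 values shown sit. Compound 3 `Cc1cc(NC(=O)Cn2cc(-c3ccc(F)cc3)nn2)no1` differs from compound 1 by fluoro in place of methoxy on an aromatic carbon. In this assay compound 3 gives > 30000 nM, again a limit and not a number. The step that the two limits leave unreadable from compound 1 to compound 3 therefore cannot be sized from these two results. Compound 4 `Cc1csc(NC(=O)Cn2cc(-c3ccc(F)cc3)nn2)n1` is not yet measured; it differs from compound 3 by 4-methyl-1,3-thiazol-2-yl in place of 5-methyl-1,2-oxazol-3-yl on an amide-type nitrogen, the same change at the same place that turned compound 1 into compound 2. The expectation for compound 4 rests on that earlier result, since compound 3 starts from the same limit that compound 1 did. Carried over from an at least 7.7-fold lower number from compound 1 to compound 2 (0.88 log units; beyond the scatter), the expected step is an at least 6.0-fold lower number from compound 3 to compound 4 (0.77 log units; beyond the scatter). Compound 4 is expected to give 5000 nM in this assay, with a likely range from 1500 nM to 30000 nM.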

Compound 4, half-maximal inhibitory concentration: 250 nM
Beside the measured number, compound 4's estimate is 20-fold (1.30 log units) above it, outside the stated range (below it).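

In this assay, 4-methyl-1,3-thiazol-2-yl in place of 5-methyl-1,2-oxazol-3-yl on the amide nitrogen again lowers the number, now on the fluoro core, with an at least 120-fold lower number from compound 3 to compound 4 (2.07 log units; beyond the scatter), so the direction of the change carries over from the methoxy core of compound 1 to the fluoro core of compound 3. The size of the change is a separate matter, and setting the two steps side by side does not settle whether it carries over too: the same change on two cores in this assay, an at least 7.7-fold lower number (0.88 log units; beyond the scatter) from compound 1 to compound 2 and an at least 120-fold lower number (2.07 log units; beyond the scatter) from compound 3 to compound 4; the limit leaves it open whether they differ The other change can be read on only one amide partner: with 4-methyl-1,3-thiazol-2-yl in place, fluoro in place of methoxy gives a 16-fold lower number from compound 2 to compound 4 (1.19 log units; beyond the scatter), whereas with 5-methyl-1,2-oxazol-3-yl in place the same change cannot be read, so nothing shows whether the two changes act independently of each other.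

With only two groups shown on the aromatic ring and two rings on the amide nitrogen, it remains open whether the gain from 4-methyl-1,3-thiazol-2-yl would hold with a chloro, an amine or a carboxylic acid on the aromatic ring. From the compounds shown here alone, it is also open how a longer chain, such as an ethyl group in place of the methyl on that ring, would fare in this assay.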